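Swapping the Amide Side Chain: Lipophilicity Unchanged So Far

This account rests on a few compounds, and the source may have more. Where it says the series, first, only, none or still open, it means among the compounds named here.

Compound 1 `CCOc1ccccc1-c1ccc(-c2nc3cnccc3c(N[C@H](CC)C(N)=O)c2C#N)cc1`: 3
Compound 2 `CCOc1ccccc1-c1ccc(-c2nc3cnccc3c(NC(C(N)=O)C3CC3)c2C#N)cc1`: 3
Compound 3 `CCOc1ccccc1-c1ccc(-c2nc3cnccc3c(C[C@H](C)C(N)=O)c2C#N)cc1`: 3

All three were read in a physicochemical assay for lipophilicity, read by HPLC, at pH 7.5; on this read-out higher numbers stand for higher lipophilicity and lower numbers for lower lipophilicity. Compound 3 stands level with compounds 1 and 2: no change at the digits printed from compound 1 to compound 3 (within the scatter) and no change at the digits printed from compound 2 to compound 3 (within the scatter), just as no change at the digits printed from compound 1 to compound 2 (within the scatter). Compound 4 `CCOc1ccccc1-c1ccc(-c2nc3cnccc3c(N[C@H](CC)C(=O)N(C)C)c2C#N)cc1` has not been measured. The change is (1-(dimethylcarbamoyl)propyl)amino in place of 2-carbamoylpropyl on an aromatic carbon. The steps from compounds 1 and 2 to compound 3, which exchanged side chains at the same position of the shared core, bear on it most closely, and both were flat. Among the measured compounds shown here, no measured step covers the dimethylcarbamoyl group itself, so the expectation rests on those flat steps, with room for a modest rise. For compound 4 in this assay a step of a number 0.30 log units higher from compound 3 to compound 4 (within the scatter) is expected, giving an estimate of 3.3 within 2.8 to 3.8.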

Compound 4, distribution coefficient: 3.7
Beside the measured number, compound 4's estimate is 0.40 log units below it; low and high end bracket the measured number.
By their numbers in this assay, from the lowest: compounds 1, 2 and 3 (each within the scatter of the next); then compound 4.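

In this assay the core's side chain finally registers a change: dimethylamino in place of amino on the carbonyl carbon gives a number 0.70 log units higher from compound 1 to compound 4 (beyond the scatter) and so moves the number beyond the scatter, which no swap among compounds 1, 2 and 3 did. Against the other two, the result is a number 0.70 log units higher from compound 2 to compound 4 (beyond the scatter) and a number 0.70 log units higher from compound 3 to compound 4 (beyond the scatter) in the same assay. Nothing measured here explains the rise. The compounds shown leave open whether a single methyl on the amide nitrogen would give part of this step, and whether diethylamino there would extend it.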